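Replacing Diethylamino with Nitro on the Shared Core

The source may hold more compounds than are shown below. What is called first, only, known or untested is meant among the compounds shown, and "the series" means these compounds.

In a functional assay on the whole organism with Rattus norvegicus as the target (a higher number here means that more compound is needed for the effect, a lower number that less compound is needed), compound 1 (`CCOC(=O)C(=O)Nc1cccc(N)c1C#N`) gives 0.05 mg/kg, compound 2 (`CCOC(=O)C(=O)Nc1cccc(N(C)CC)c1C#N`) gives 0.3 mg/kg and compound 3 (`CCOC(=O)C(=O)Nc1cccc(N(CC)CC)c1C#N`) gives 0.7 mg/kg, the highest of the three numbers. Among these compounds the number rises as alkyl chains are added to the amino group, with a modest step of a 6.0-fold higher number from compound 1 to compound 2 (0.78 log units; beyond the scatter), another modest step a 2.3-fold higher number from compound 2 to compound 3 (0.37 log units; beyond the scatter) and a large step overall a 14-fold higher number from compound 1 to compound 3 (1.15 log units; beyond the scatter). Compound 4 (`CCOC(=O)C(=O)Nc1cccc([N+](=O)[O-])c1C#N`) has not yet been measured. It differs from compound 3 as follows: nitro in place of diethylamino on an aromatic carbon. The new group sits ortho to a cyano group.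

Among the measured compounds shown here, no measured compound carries nitro, so the evidence is indirect. The closest guide is the large step of a 14-fold higher number from compound 1 to compound 3 (1.15 log units; beyond the scatter), which shows that the diethylamino group of compound 3 goes with a higher number than amino. Nitro is not amino, so only part of that gap is expected to be recovered. A modest drop is therefore expected, with an estimated step of a 3.5-fold lower number from compound 3 to compound 4 (0.54 log units; beyond the scatter). For compound 4 the estimated value is 0.2 mg/kg, with an expected range of 0.05 mg/kg to 0.8 mg/kg.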

Compound 4, dose for half-maximal effect: 0.4 mg/kg
Estimate against measurement, compound 4: 2.0-fold (0.30 log units) below; the range from low to high includes it.
By their numbers in this assay, from the lowest: compound 1; then compounds 2, 4 and 3 (each within the scatter of the next, the first and the last beyond it).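

At this position, on an aromatic carbon ortho to a cyano group, nitro cannot be told apart from diethylamino in this assay, with a 1.8-fold lower number from compound 3 to compound 4 (0.24 log units; within the scatter) lying within the scatter, and the same holds against ethyl(methyl)amino, with a 1.3-fold higher number from compound 2 to compound 4 (0.12 log units; within the scatter) also within the scatter. Compound 4 carries no alkyl chain on this carbon, yet amino still stands apart, with an 8.0-fold higher number from compound 1 to compound 4 (0.90 log units; beyond the scatter) beyond the scatter, so among these compounds the absence of alkyl chains alone does not go with the number of compound 1. No measurement accompanying these values bears on why this is so.

Going by these compounds, it remains open whether the number of compound 1 is specific to amino or would also appear with methylamino or hydroxyl here. On these data alone, it is also open how these groups would rank with a hydrogen or a carboxylic acid in place of the nitrile.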